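This account rests on a few compounds, and the source may have more. Where it says the series, first, only, none or still open, it means among the compounds named here.

Three closely related compounds have been tested in a functional assay on HEL cells (Homo sapiens) for cytotoxicity, read by microscopy; on this read-out higher numbers stand for lower toxicity in this test and lower numbers for higher toxicity in this test. Compound 1 `Cc1cn([C@@H]2O[C@H](CO[Si](C)(C)C(C)(C)C)[C@@]3(OS(=O)(=O)C=C3NCC(N)=O)[C@H]2O[Si](C)(C)C(C)(C)C)c(=O)n(C)c1=O` gives 16000 nM. Compound 2 `CCOC(=O)CNC(=O)NC1=CS(=O)(=O)O[C@@]12[C@@H](CO[Si](C)(C)C(C)(C)C)O[C@@H](n1cc(C)c(=O)n(C)c1=O)[C@@H]2O[Si](C)(C)C(C)(C)C` gives 16000 nM in this assay, and compound 3 `Cc1cn([C@@H]2O[C@H](CO[Si](C)(C)C(C)(C)C)[C@@]3(OS(=O)(=O)C=C3NC(N)=O)[C@H]2O[Si](C)(C)C(C)(C)C)c(=O)n(C)c1=O` gives 16000 nM. On these numbers compound 2 stands level with compounds 1 and 3: the step of no change at the digits printed from compound 1 to compound 2 (within the scatter) and the step of no change at the digits printed from compound 2 to compound 3 (within the scatter) both stay within the scatter, as does no change at the digits printed from compound 1 to compound 3 (within the scatter). Each of these changes exchanged the group on the amine nitrogen of the shared core, and none of them moved the read-out.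

Compound 4 `Cc1cn([C@@H]2O[C@H](CO[Si](C)(C)C(C)(C)C)[C@@]3(OS(=O)(=O)C=C3NCCC(=O)OCc3ccccc3)[C@H]2O[Si](C)(C)C(C)(C)C)c(=O)n(C)c1=O` has not yet been tested. It differs from compound 2 at that same place: 2-(benzyloxycarbonyl)ethyl in place of ((ethoxycarbonyl)methyl)carbamoyl on an amine nitrogen. The measured steps that bear on it are no change at the digits printed from compound 1 to compound 2 (within the scatter) and no change at the digits printed from compound 2 to compound 3 (within the scatter), which also swapped the group on this amine nitrogen and showed no change beyond the scatter. In this assay a step of no more than the scatter, in either direction, is therefore expected, no change at the digits printed from compound 2 to compound 4 (within the scatter). Compound 4 is estimated at 16000 nM, with a range from 8000 nM to 32000 nM.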

Compound 4, minimum cytotoxic concentration: >= 400000 nM
Compound 4 ended at the assay's limit; the forecaster's own chance of this, stated with the estimate: 30%; at least 25-fold (1.39 log units) between middle value and limit.
By their numbers in this assay, from the lowest: compounds 1, 2 and 3 (each within the scatter of the next). At a limit, above all of these: compound 4.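

The group on this amine nitrogen does matter in this assay, although the earlier exchanges there left the read-out flat. With 2-(benzyloxycarbonyl)ethyl on the nitrogen, the data show an at least 25-fold higher number from compound 2 to compound 4 (1.39 log units; beyond the scatter), and likewise an at least 25-fold higher number from compound 3 to compound 4 (1.39 log units; beyond the scatter) and an at least 25-fold higher number from compound 1 to compound 4 (1.39 log units; beyond the scatter), so lower toxicity in this test than for the other three compounds. The figure for compound 4 is a limit of the assay, not a number: the limit of >= 400000 nM in this assay, at which 1 of the 4 values shown sits.

Compared with compound 2, the entering group brings a six-membered aromatic ring and has no hydrogen-bond donor, and the compounds shown cannot tell which of these differences goes with the higher number. As far as these compounds go, whether a 2-(ethoxycarbonyl)ethyl group, which keeps the chain and ester without the aromatic ring, or a plain carboxylic acid on the same chain would also reach the limit remains open.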